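This account rests on a few compounds, and the source may have more. Where it says the series, first, only, none or still open, it means among the compounds named here.

In a functional assay on MDA-MB-231 cells (Homo sapiens) for antiproliferative activity, read by MTT assay, with a stated time of 24 h (a lower number here means a stronger inhibitor, a higher number a weaker inhibitor), compound 1 (`O=C(O)CC(NC(=O)c1ccc(Cl)cc1Cl)c1ccccc1`) gives 67200 nM. Compound 3 (`CC(C)(C)c1ccc(C(CC(=O)O)NC(=O)c2ccc(Cl)cc2Cl)cc1`) gives 67800 nM, which places compound 1 within the scatter of it. Compound 2 (`COc1ccc(C(=O)NC(CC(=O)O)c2ccc(C(C)(C)C)cc2)cc1`) reads > 100000 nM, and this is a limit of the assay, not a number.

The step followed here leads to compound 4 (`O=C(O)CC(NC(=O)c1ccc(Cl)cc1Cl)c1ccc(Cl)cc1Cl`): 2,4-dichlorophenyl in place of phenyl on a saturated chain carbon bound to an amide-type nitrogen and a saturated chain carbon. This puts 2,4-dichlorophenyl in place of phenyl on a saturated chain carbon bound to an amide-type nitrogen and a saturated chain carbon.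

Going by the values given here, two measured steps bear on it. The closer one, tert-butyl in place of hydrogen on an aromatic carbon, gave a 1.0-fold higher number from compound 1 to compound 3 (0.00 log units; within the scatter), and it alters the same phenyl group. The other, 2,4-dichlorophenyl in place of 4-methoxyphenyl on a carbonyl carbon, gave an at least 1.4-fold lower number from compound 2 to compound 3 (0.16 log units; that floor lies within the scatter), but it lies elsewhere in the molecule and offers only a floor.

On this evidence, no step beyond the scatter is expected in this assay. The estimated step is a 1.3-fold lower number from compound 1 to compound 4 (0.11 log units; within the scatter). Compound 4 is expected to give 52000 nM, within an estimated range of 22000 nM to 100000 nM.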

Compound 4, half-maximal inhibitory concentration: 49200 nM
The estimate for compound 4 lay 1.1-fold (0.02 log units) above the measured number, and the stated range covers the measured number.
By their numbers in this assay, from the lowest: compounds 4, 1 and 3 (each within the scatter of the next). At a limit, above all of these: compound 2.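

In this assay, 2,4-dichlorophenyl in place of phenyl on a saturated chain carbon bound to an amide-type nitrogen and a saturated chain carbon gives a 1.4-fold lower number from compound 1 to compound 4 (0.14 log units; within the scatter). Going by these compounds alone, until now the only change to this phenyl group was tert-butyl in place of hydrogen on an aromatic carbon, which gave a 1.0-fold higher number from compound 1 to compound 3 (0.00 log units; within the scatter). Compound 4 adds a second, different replacement, this time bearing chlorine, and it too stays within the scatter, so neither change to this group separates its compound from compound 1.

Going by these compounds, whether any group at this place can move the number beyond the scatter stays open, as does what an amine or a hydroxyl on this ring, or an ester in place of the carboxylic acid, would do. Compound 2 remains a limit of the assay and not a number: the limit of > 100000 nM in this assay, at which 1 of the 4 values shown sits.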